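A few compounds are considered here, and "the series" means these few. Any claim that something is new, unique, unknown or untested is made for them only; others in the source may bear on it.

Working notes on the shared core. Compound 1 `CS(=O)(=O)c1ccc(Nc2ncc(F)c(Nc3nc4ccccc4s3)n2)cc1` gives 2830 nM in a functional assay on PC-3 cells (Homo sapiens) for antiproliferative activity, read by MTT assay, with a stated time of 48 h; a higher number here means a weaker inhibitor, a lower number a stronger inhibitor. Compound 2 `Cc1ccc2nc(Nc3nc(Nc4ccc(S(N)(=O)=O)cc4)ncc3C)sc2c1` gives 2710 nM in this assay. Compound 3 `NS(=O)(=O)c1ccc(Nc2ncc(F)c(Nc3nc4ccccc4s3)n2)cc1` returns only a limit in this assay, reported as > 50000 nM, so no number is available for it. For the measured compounds named here, the single one-place step measured so far, an at least 17-fold higher number from compound 1 to compound 3 (1.24 log units; beyond the scatter), runs into (the limit of > 50000 nM in this assay, at which 1 of the 3 values shown sits), and its true size is therefore not known beyond that bound. Among the numbers shown, compound 3 stands at the weak end, and it stands there as a limit rather than as a value.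

Compound 4 `Cc1cnc(Nc2ccc(S(N)(=O)=O)cc2)nc1Nc1nc2ccccc2s1` differs from compound 3 by methyl in place of fluoro on an aromatic carbon. Going by the values given here, no measured step covers this change on its own. Compound 2 carries the same methyl on the same ring together with the same sulfonamide, but also a further methyl elsewhere, so it offers only a loose pointer: with both features present, compound 2 gives 2710 nM, a number near that of compound 1. On that pointer alone, compound 4 is expected to come back from the limit, with a step estimated at an at least 6.2-fold lower number from compound 3 to compound 4 (0.79 log units; beyond the scatter). Compound 4 is therefore estimated at 8000 nM, within 2000 nM to 50000 nM, with a fair chance that only a limit is reported again.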

Compound 4, half-maximal inhibitory concentration: > 50000 nM
Compound 4: no number, only a limit; the forecaster's own chance of this, stated with the estimate: 25%; at least 6.2-fold (0.79 log units) between middle value and limit.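

With methyl in place of fluoro on the aromatic carbon, compound 4 in this assay gives > 50000 nM, which is a limit and not a number. With amino on the sulfonyl sulfur, neither fluoro nor methyl at this position therefore gives a number, and the step between compound 3 and compound 4 cannot be read: the limit of > 50000 nM in this assay, at which 2 of the 4 values shown sit.

For the compounds shown here, the one readable new step lies elsewhere on the shared core: hydrogen in place of methyl on an aromatic carbon gives an at least 18-fold higher number from compound 2 to compound 4 (1.26 log units; beyond the scatter), so in this pair the measurable value goes with the further methyl, not with the methyl at this position alone.

From the compounds shown here alone, it remains open how methyl in place of fluoro at this position acts when the sulfonyl sulfur carries methyl, as in compound 1, where a number could show a step that the two limits hide. Also open, going by these compounds, is whether a chlorine, a methoxy group or an amine at this position, or any of these in place of the further methyl of compound 2, would give a number with amino on the sulfonyl sulfur.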